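Replacing the hydrazide aryl group of compound 1 with a benzoyl

A few compounds are considered here, and "the series" means these few. Any claim that something is new, unique, unknown or untested is made for them only; others in the source may bear on it.

Compound 1 `Cc1ccccc1NNC(=O)c1ccc(NS(=O)(=O)c2cnc(O)nc2O)cc1` carries a 2-methylphenyl group on an amine nitrogen of the shared core. In a functional assay on MDA-MB-231 cells (Homo sapiens) for antiproliferative activity, read by MTT assay, with a stated time of 24 h (on this read-out lower numbers stand for stronger inhibition and higher numbers for weaker inhibition), compound 1 gives > 20000 nM, which is a limit of the assay rather than a number. Compound 2 `Cc1cccc(NNC(=O)c2cccc(NS(=O)(=O)c3cnc(O)nc3O)c2)c1` gives in this assay > 20000 nM, again only a limit. Compound 3 `O=C(NNc1ccccc1F)c1cccc(NS(=O)(=O)c2cnc(O)nc2O)c1` gives in this assay > 20000 nM, likewise a limit. All three values sit at the limit of > 20000 nM in this assay, at which 3 of the 3 values shown sit. Among the compounds with values here, the single step among the measured compounds, a step that the two limits leave unreadable from compound 2 to compound 3, changes the aryl group on the same amine nitrogen, yet its size cannot be read.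

Compound 4 `O=C(NNC(=O)c1cccc(Cl)c1)c1ccc(NS(=O)(=O)c2cnc(O)nc2O)cc1` differs from compound 1 in one place: (3-chlorophenyl)carbonyl in place of 2-methylphenyl on an amine nitrogen. Within the data shown here, no measured step gives a readable size for a change of this kind, so the expectation rests on the limits alone. The step so estimated, a number no higher from compound 1 to compound 4 (the limit leaves the size open), is expected to be none beyond the scatter. Compound 4 is therefore expected to give 20000 nM, with a range from 6000 nM to 60000 nM, most likely reported again as a limit.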

Compound 4, half-maximal inhibitory concentration: 4160 nM
The estimate for compound 4 lay 4.8-fold (0.68 log units) above the measured number; the measured number lies below the stated range.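

In this assay, placing (3-chlorophenyl)carbonyl instead of 2-methylphenyl on the amine nitrogen gives an at least 4.8-fold lower number from compound 1 to compound 4 (0.68 log units; beyond the scatter). Within the data shown here, this is the first readable size at this position, and it shows that the number here can move clear of the limit when the group on that nitrogen changes. The earlier compounds, all with an aryl group directly on that nitrogen, gave no such reading, and compound 4 alone stands off the limit: the limit of > 20000 nM in this assay, at which 3 of the 4 values shown sit.

The change brings in a carbonyl and a chlorine and removes a methyl in one step, so the compounds shown do not tell which of these parts carries the gain. As far as these compounds go, whether a plain benzoyl or an acetyl group on the same nitrogen would also move the number off the limit stays open.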